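Amine substitution on the octadecyl threonine amide scaffold

The source may hold more compounds than are shown below. What is called first, only, known or untested is meant among the compounds shown, and "the series" means these compounds.

Measured so far:
compound 1 `CCCCCCCCCCCCCCCCCCNC(=O)[C@@H](N)[C@@H](C)O` — 21300 nM
compound 2 `C/C=C/C=C/C(=O)N[C@H](C(=O)NCCCCCCCCCCCCCCCCCC)[C@@H](C)O` — 187000 nM

In a functional assay on A-431 cells (Homo sapiens) for cytotoxicity, read by MTT assay, with a stated time of 48 h (a lower number here means a stronger inhibitor, a higher number a weaker inhibitor), compound 2 gives the highest of the two numbers; its nearest neighbour is compound 1, and the step of an 8.8-fold higher number from compound 1 to compound 2 (0.94 log units; beyond the scatter) lies beyond the scatter. Compound 3 `CCCCCCCCCCCCCCCCCCNC(=O)[C@@H](NS(=O)(=O)c1ccc(C)cc1)[C@@H](C)O` differs from compound 2 by (4-methylphenyl)sulfonyl in place of (penta-1,3-dien-1-yl)carbonyl on an amine nitrogen. Among the compounds with values here, only the step from compound 1 to compound 2 bears on this change: it shows that occupying the amine nitrogen raised the number in this assay, so compound 3, which also carries a substituent there, is expected to stay near compound 2, with no step beyond the scatter, a 1.6-fold lower number from compound 2 to compound 3 (0.19 log units; within the scatter). Compound 3 is therefore estimated at 120000 nM, within 35000 nM to 400000 nM.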

Compound 3, half-maximal inhibitory concentration: 34000 nM
The estimate for compound 3 lay 3.5-fold (0.55 log units) above the measured number; measured number outside the range, below it.
By their numbers in this assay, from the lowest: compounds 1 and 3 (each within the scatter of the next); then compound 2.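

In this assay a substituent on the amine nitrogen does not by itself raise the number: the change to (4-methylphenyl)sulfonyl gives a 5.5-fold lower number from compound 2 to compound 3 (0.74 log units; beyond the scatter) and, against the free amine, a 1.6-fold higher number from compound 1 to compound 3 (0.20 log units; within the scatter) within the scatter. The outcome at this nitrogen therefore depends on which group sits there, and of the two groups tested only (penta-1,3-dien-1-yl)carbonyl separates from compound 1. No available evidence accounts for the difference between the two groups.

From the compounds shown here alone, whether a simple acetyl or a benzoyl on this nitrogen would track compound 2 or compound 3 remains open, as does whether the carbonyl or sulfonyl link or the rest of the group sets the number.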